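From compound 1 to compound 4: fluoro to hydrogen

A few compounds are considered here, and "the series" means these few. Any claim that something is new, unique, unknown or untested is made for them only; others in the source may bear on it.

compound 1 `Cc1nn(-c2ccccc2)c2nc(OCc3ccccc3F)c(-c3nc(N)cc(N)n3)cc12`: 2200 nM
compound 2 `Cc1nn(-c2ccccc2)c2nc(OCc3ccccc3F)c(-c3nc(N)c(NC(=O)OC4CCCC4)c(N)n3)cc12`: limit, > 100000 nM
compound 3 `Cc1nn(-c2ccccc2)c2nc(OCc3ccccc3F)c(-c3nc(N)c(N4CCOC4=O)c(N)n3)cc12`: limit, > 100000 nM

Going by the values given here, in a functional assay on aorta (Rattus norvegicus, strain Sprague-Dawley) (on this read-out higher numbers stand for an effect only at larger amounts of compound and lower numbers for an effect already at smaller amounts), compound 1 gives 2200 nM, the only true number. Compound 2 and compound 3 each have a limit in place of a number. Compound 4 `Cc1nn(-c2ccccc2)c2nc(OCc3ccccc3)c(-c3nc(N)cc(N)n3)cc12` carries hydrogen in place of fluoro on an aromatic carbon, turning 2-fluorobenzyl into benzyl (hydrogen in place of fluoro on an aromatic carbon). The measured steps are large, an at least 45-fold higher number from compound 1 to compound 2 (1.65 log units; beyond the scatter) and an at least 45-fold higher number from compound 1 to compound 3 (1.65 log units; beyond the scatter), but neither touches the 2-fluorobenzyl group, so neither bears directly on this change. With no measured guide at this group, no step beyond the scatter is expected in this assay, and the estimate is a 1.4-fold higher number from compound 1 to compound 4 (0.13 log units; within the scatter). For compound 4 the expected value is 3000 nM, within an estimated range of 1000 nM to 10000 nM.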

Compound 4, half-maximal effective concentration: 10800 nM
For compound 4 the middle estimate is 3.6-fold (0.56 log units) below the measured one; measured number above the stated range.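

In this assay, going by these compounds alone, the change at the 2-fluorobenzyl group gives the first step with a readable size, a 4.9-fold higher number from compound 1 to compound 4 (0.69 log units; beyond the scatter) and so the fluoro matters at this place, modestly. The earlier steps shown here, made at a different place on the shared core, ended only in limits. Nothing measured here accounts for this step.

Open, as far as these compounds go, is whether chloro or methyl at this place would match the fluoro. Also open, from the compounds shown here alone, is whether a fluoro elsewhere on the six-membered aromatic ring would hold the same number.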